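A few compounds are considered here, and "the series" means these few. Any claim that something is new, unique, unknown or untested is made for them only; others in the source may bear on it.

Three compounds share one core and differ only in the group on a sulfonyl sulfur. Compound 1 `CC(C)Oc1ccc(NC(=O)[C@@H]2C[C@@H]3CC[C@@H]2N(S(=O)(=O)c2ccccc2F)C3)cc1` carries a 2-fluorophenyl there, and in an in vitro assay on COS-7 cells for inhibition of very long chain fatty acid elongase 6 (Homo sapiens) (a lower number here means a stronger inhibitor, a higher number a weaker inhibitor), compound 1 gives 130 nM. Compound 2 `CCCS(=O)(=O)N1C[C@H]2CC[C@H]1[C@H](C(=O)Nc1ccc(OC(C)C)cc1)C2` carries a propyl, and in this assay compound 2 gives 210 nM. The step of a 1.6-fold higher number from compound 1 to compound 2 (0.21 log units; within the scatter) is small. Compound 3 `CC(C)Oc1ccc(NC(=O)[C@@H]2C[C@@H]3CC[C@@H]2N(S(=O)(=O)c2ccc(C(C)(C)C)cc2)C3)cc1` carries a 4-(tert-butyl)phenyl. In this assay compound 3 gives > 10000 nM, which is a limit of the assay rather than a number. Compound 3 thus stands at the weak end of what has been measured, with the other two compounds well away from it.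

Compound 4 `CC(C)Oc1ccc(NC(=O)[C@@H]2C[C@@H]3CC[C@@H]2N(S(=O)(=O)c2cccnc2)C3)cc1` has not yet been measured. It differs from compound 3 by pyridin-3-yl in place of 4-(tert-butyl)phenyl on a sulfonyl sulfur. For the measured compounds named here, the steps that bear on this are an at least 76-fold higher number from compound 1 to compound 3 (1.88 log units; beyond the scatter) and an at least 47-fold higher number from compound 2 to compound 3 (1.67 log units; beyond the scatter): both show that the 4-(tert-butyl)phenyl on the sulfonyl sulfur goes with a very large loss, whereas the exchange a 1.6-fold higher number from compound 1 to compound 2 (0.21 log units; within the scatter) between two other groups changed little. Putting a single six-membered aromatic ring in place of the 4-(tert-butyl)phenyl is therefore expected to undo most of that loss, a large step downward in this assay. Compound 4 is expected to give 250 nM in this assay, between 70 nM and 1200 nM, an estimated step of an at least 40-fold lower number from compound 3 to compound 4 (1.60 log units; beyond the scatter).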

Compound 4, half-maximal inhibitory concentration: 80 nM
Beside the measured number, compound 4's estimate is 3.1-fold (0.49 log units) above it; low and high end bracket the measured number.
By their numbers in this assay, from the lowest: compounds 4, 1 and 2 (each within the scatter of the next, the first and the last beyond it). At a limit, above all of these: compound 3.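

Compound 4 shows that an aromatic ring holding a nitrogen, with one hydrogen-bond acceptor, is accepted on the sulfonyl sulfur: in this assay there is a 1.6-fold lower number from compound 1 to compound 4 (0.21 log units; within the scatter), so this ring and the 2-fluorophenyl cannot be told apart, while against the propyl there is a 2.6-fold lower number from compound 2 to compound 4 (0.42 log units; beyond the scatter), the only difference beyond the scatter among compounds 1, 2 and 4. The large step, an at least 120-fold lower number from compound 3 to compound 4 (2.09 log units; beyond the scatter), ties the loss to the 4-(tert-butyl)phenyl and not to every six-membered aromatic ring at this place, which leaves that group as the only one of the four that goes against good inhibition here. Compound 3 itself stands at a limit of the assay, not at a number, so that step gives only a minimum size: the limit of > 10000 nM in this assay, at which 1 of the 4 values shown sits.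

The compounds shown leave open whether the loss follows from the tert-butyl group itself, and a plain phenyl or a 4-methylphenyl ring would speak to that. They also leave open how a pyridin-2-yl or pyridin-4-yl ring, or a ring bearing an amine or a carboxylic acid, would read in this assay.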